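Moving One Methyl Group on a Tolerated Compound

The source may hold more compounds than are shown below. What is called first, only, known or untested is meant among the compounds shown, and "the series" means these compounds.

Among the compounds with values here, in an ADME assay on MT4 cells (Homo sapiens) for cytotoxicity, read by MTT assay, with a stated time of 4 days (a higher number here means that more compound is tolerated, a lower number that less compound is tolerated), compound 1 `CC(C)N(C)c1nc(Cc2c(F)cccc2F)cc(=O)[nH]1` gives 85000 nM as the only true number so far. Compound 2 `CC1CCCCN1c1nc(Cc2c(F)cccc2F)cc(=O)[nH]1` gives > 78000 nM which is a limit and not a number. Within the data shown here, the one measured step is a step that the limit leaves unreadable from compound 1 to compound 2 and so it offers no size to carry forward. The evidence is thin: the limit of > 78000 nM in this assay, at which 1 of the 2 values shown sits, and nothing firmer.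

The change from compound 2 to compound 3 `CC1CCN(c2nc(Cc3c(F)cccc3F)cc(=O)[nH]2)CC1` is 4-methylpiperidin-1-yl in place of 2-methylpiperidin-1-yl on an aromatic carbon and the atoms stay the same while being joined differently. Among the measured compounds shown here, no measured step speaks to such a move, so no change beyond the usual scatter is expected in this assay and no direction is favoured. For the measured compounds named here, compound 1 at 85000 nM gives the one number for this expectation to lean on. The estimated step is a step that the limit leaves unreadable from compound 2 to compound 3 and it may again be hidden behind a limit. Compound 3 is expected near 80000 nM with a range from 40000 nM to 150000 nM as the estimate.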

Compound 3, half-maximal cytotoxic concentration: > 78000 nM
Compound 3: no number, only a limit; the forecaster's own chance of this, stated with the estimate: 45%; the middle value does not contradict the limit.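

In this assay compound 3 gives > 78000 nM, which is a limit and not a number. Within the data shown here, compound 2 also has only a limit, so no step among compound 1, compound 2 and compound 3 can be read. Still open, going by these compounds, is whether 4-methylpiperidin-1-yl and 2-methylpiperidin-1-yl differ in how much compound is tolerated.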